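Lengthening the chain on compound 3

The source may hold more compounds than are shown below. What is called first, only, known or untested is meant among the compounds shown, and "the series" means these compounds.

Measured so far in a functional assay on MGC-803 cells (Homo sapiens) for antiproliferative activity, read by MTT assay, with a stated time of 48 h (on this read-out higher numbers stand for weaker inhibition and lower numbers for stronger inhibition), for three compounds

compound 1 `CCCCCCCn1cc(COC[C@@H]2OC[C@H](N)[C@@H]2O)nn1` gives > 128000 nM (a limit)
compound 2 `CCCCCCCCCn1cc(COC[C@@H]2OC[C@H](N)[C@@H]2O)nn1` gives 13800 nM
compound 3 `CCCCCCCn1cc(COC[C@@H]2OC[C@H](N)[C@H]2O)nn1` gives > 128000 nM (a limit)

Compound 3 gives > 128000 nM as a limit and not a number. The change to compound 4 `CCCCCCCCCCn1cc(COC[C@@H]2OC[C@H](N)[C@H]2O)nn1` is propyl in place of hydrogen on a saturated chain carbon, seven bonds along the chain from an aromatic nitrogen and reads in words as propyl in place of hydrogen on a saturated chain carbon, seven bonds along the chain from an aromatic nitrogen. The closest measured precedent is an at least 9.2-fold lower number from compound 1 to compound 2 (0.96 log units; beyond the scatter) and it is a change of the same kind at the same place, with ethyl entering, in the other configuration. Among the measured compounds shown here, the configuration itself stays open, as the only measured comparison is a step that the two limits leave unreadable from compound 1 to compound 3 and it gives no size. A lower number beyond the scatter is therefore expected. The expected change is an at least 12-fold lower number from compound 3 to compound 4 (1.10 log units; beyond the scatter) in this assay and it rests on a single precedent. Compound 2 at 13800 nM is the nearest measured value and anchors the expectation. Compound 4 is estimated at 10000 nM with 3000 nM to 40000 nM as its expected range.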

Compound 4, half-maximal inhibitory concentration: 57400 nM
Estimate against measurement, compound 4: 5.7-fold (0.76 log units) below; the whole stated range lies below it.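

In this assay compound 3 gives > 128000 nM, a limit and not a number. Propyl in place of hydrogen at this place brings the configuration of compound 3 to a measured value, giving an at least 2.2-fold lower number from compound 3 to compound 4 (0.34 log units; beyond the scatter). Among the compounds shown here, until now, lengthening the chain had been seen only in the other configuration, as an at least 9.2-fold lower number from compound 1 to compound 2 (0.96 log units; beyond the scatter), and since both steps start from a limit, their sizes cannot be set against each other.

From the compounds shown here alone, the step from compound 1 to compound 3 cannot be read, so the effect of configuration stays open, because both values sit at: the limit of > 128000 nM in this assay, at which 2 of the 4 values shown sit. Whether a longer chain, such as dodecyl, or a cyclohexyl group at the same place would lower the number further also remains open.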